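Changing the aryl group on a shared core

The source may report more compounds than this note shows. Statements on the series, on what has been measured and on what is new or still open speak of the compounds shown alone.

Two compounds sharing one core have numbers in a functional assay on MV4-11 cells (Homo sapiens) for antiproliferative activity, read by CCK-8 assay, with a stated time of 72 h; on this read-out lower numbers stand for stronger inhibition and higher numbers for weaker inhibition: compound 1 `Cc1cc(F)cc(C)c1Oc1ccc(C(C)(C)O)cc1-c1cn(C)c(=O)c2[nH]c(C(=O)NCc3ccc(C(=O)Nc4ccccc4N)cc3)cc12` gives 240 nM and compound 2 `CC(C)Oc1ccccc1-c1cn(C)c(=O)c2[nH]c(C(=O)NCc3ccc(C(=O)Nc4ccccc4N)cc3)cc12` gives 130 nM, values within the usual scatter of each other. Compound 3 `COc1ccc(C(C)(C)O)cc1-c1cn(C)c(=O)c2[nH]c(C(=O)NCc3ccc(C(=O)Nc4ccccc4N)cc3)cc12` differs from compound 2 in one place, with 5-(1-hydroxy-1-methylethyl)-2-methoxyphenyl in place of 2-isopropoxyphenyl on an aromatic carbon. The 1-hydroxy-1-methylethyl group also occurs in compound 1, at 240 nM, so no step beyond the scatter is expected in this assay. The expected change is small: a 1.2-fold higher number from compound 2 to compound 3 (0.09 log units; within the scatter). For compound 3 the estimate is 160 nM, with an expected range from 70 nM to 350 nM.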

Compound 3, half-maximal inhibitory concentration: 420 nM
Beside the measured number, compound 3's estimate is 2.6-fold (0.42 log units) below it; the whole stated range lies below it.
By their numbers in this assay, from the lowest: compounds 2, 1 and 3 (each within the scatter of the next, the first and the last beyond it).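

In this assay, 5-(1-hydroxy-1-methylethyl)-2-methoxyphenyl in place of 2-isopropoxyphenyl gives a 3.2-fold higher number from compound 2 to compound 3 (0.51 log units; beyond the scatter) and so shows that this aromatic carbon responds modestly to a change of aryl group. With the 1-hydroxy-1-methylethyl group present in both compounds, methyl in place of 4-fluoro-2,6-dimethylphenyl on the oxygen gives a 1.8-fold higher number from compound 1 to compound 3 (0.24 log units; within the scatter) and stays within the scatter. No supporting measurement bears on why the first step occurs. On these data alone, it remains open whether that step follows the 1-hydroxy-1-methylethyl group or the methoxy group, and a plain 2-methoxyphenyl group would separate the two.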